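This account rests on a few compounds, and the source may have more. Where it says the series, first, only, none or still open, it means among the compounds named here.

Measured compounds:
- compound 1, `O=C(Cn1nnc(-c2ccccc2)n1)Nc1cc(C2(C(F)(F)F)CC2)nn1C1CCCCC1`: "not active" (no number reported)
- compound 2, `O=C(Cn1nnc(-c2ccccc2)n1)Nc1ccccn1`: "not active" (no number reported)
- compound 3, `Cc1cc(NC(=O)Cn2nnc(-c3cccc(F)c3)n2)n(C2CCCCC2)n1`: 81 nM

For the measured compounds named here, in an assay on HEK293 cells for activation of Kir3.1/Kir3.2 (Homo sapiens), read by thallium flux (on this read-out lower numbers stand for an effect already at smaller amounts and higher numbers for an effect only at larger amounts of compound), compound 3 is the only compound of the three for which a number is reported; compound 1 and compound 2 are recorded without one. Going by the values given here, compound 3 thus stands alone as the reference point, and the two entries without a number give no step against which to weigh it.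

Compound 4, `Cc1cc(NC(=O)Cn2nnc(-c3ccc(Cl)c(C)c3)n2)n(C2CCCCC2)n1`, is the next compound to be measured. It differs from compound 3 in one place: 4-chloro-3-methylphenyl in place of 3-fluorophenyl on an aromatic carbon. Among the compounds with values here, no step between two measured compounds covers a change at this position, so there is nothing in the data to say how large an effect such an exchange has. Given this, the expectation for compound 4 is a step of a 1.2-fold lower number from compound 3 to compound 4 (0.06 log units; within the scatter) that stays within the scatter of repeated measurements, in no firm direction. Compound 4 is therefore estimated at 70 nM in this assay, with a range from 18 nM to 280 nM reflecting the absence of a comparable step.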

Compound 4, half-maximal effective concentration: 712 nM
Compound 4: middle estimate off by 10-fold (1.01 log units), on the low side; measured number above the stated range.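

For the compounds shown here, the aryl group on this aromatic carbon of the five-membered aromatic ring with 4 nitrogen turns out to matter: in this assay, 4-chloro-3-methylphenyl in place of 3-fluorophenyl gives an 8.8-fold higher number from compound 3 to compound 4 (0.94 log units; beyond the scatter) and thus the first readable step, one that lies beyond the scatter. The exchange raises the number but does not remove the effect, so this position tolerates the larger group to a measurable degree. No measurement at hand bears on what lies behind this step.

The exchange alters the chlorine, the methyl and the fluorine together, and the compounds shown do not separate their shares in the step. From the compounds shown here alone, how an aryl group carrying an amine or a methoxy group would read at this position also remains open.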